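Swapping isopropyl for phenyl: an expected gain in inhibition

This account rests on a few compounds, and the source may have more. Where it says the series, first, only, none or still open, it means among the compounds named here.

Compound 3 `CC(C)COc1ccccc1C1CC(=O)c2ccccc2O1` stands lowest of three compounds in a functional assay on J774.A1 cells (Mus musculus) for inhibition, read by immunoassay, with a stated time of 12 h, tested at 30 uM (on this read-out higher numbers stand for more inhibition at the one concentration tested (going by the name of the read-out) and lower numbers for less inhibition), where compound 3 gives 33.5%. Compound 1 `CCCOc1ccccc1C1CC(=O)c2ccccc2O1` gives 43.6%, and compound 2 `CC(C)c1ccc(COc2ccccc2C2CC(=O)c3ccccc3O2)cc1` gives 91.7%. The step of a number 10.1 percentage points lower from compound 1 to compound 3 (beyond the scatter) is modest, whereas a number 48.1 percentage points higher from compound 1 to compound 2 (beyond the scatter) and a number 58.2 percentage points lower from compound 2 to compound 3 (beyond the scatter) are both large. Compound 4 `O=C1CC(c2ccccc2OCc2ccccc2)Oc2ccccc21` differs from compound 3 in one place: phenyl in place of isopropyl on a saturated chain carbon bound to an oxygen on an aromatic ring. The two large steps bear on this change, since each puts a 4-isopropylphenyl in place of a chain group on a saturated chain carbon bound to an oxygen on an aromatic ring. The entering phenyl lacks the isopropyl of compound 2. Because of a number 58.2 percentage points lower from compound 2 to compound 3 (beyond the scatter), a large rise is still expected for compound 4, estimated as a number 36.5 percentage points higher from compound 3 to compound 4 (beyond the scatter). Compound 4 is therefore estimated at 70%, between 45% and 90%.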

Compound 4, a percentage reported as inhibition, at one concentration (the size of the read-out at that concentration, not a potency): 91.5%
Estimate against measurement, compound 4: 21.5 percentage points below, outside the stated range (above it).
By their numbers in this assay, from the lowest: compound 3; then compound 1; then compounds 4 and 2 (each within the scatter of the next).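

The gain at this place comes with the plain phenyl: in this assay the rise is large both (a number 58 percentage points higher from compound 3 to compound 4 (beyond the scatter)) and (a number 47.9 percentage points higher from compound 1 to compound 4 (beyond the scatter)). The earlier compounds shown here could not separate the ring from its isopropyl, but (a number 0.2 percentage points lower from compound 2 to compound 4 (within the scatter)) shows that inhibition at this level does not need the isopropyl on the aromatic carbon. Nothing given here accounts for the gain.

A single concentration leaves open whether compound 2 and compound 4 differ in potency. Going by these compounds, it also remains open how a pyridine ring, or an amine or a carboxylic acid on the phenyl, would fare at this place.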